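The source may report more compounds than this note shows. Statements on the series, on what has been measured and on what is new or still open speak of the compounds shown alone.

Measured in an ADME assay on HEK293 cells (Homo sapiens) for cytotoxicity, read by resazurin assay, with a stated time of 48 h; a lower number here means that less compound is tolerated, a higher number that more compound is tolerated:
Compound 1 `Cc1ccc(S(=O)(=O)Nc2ccc(-c3nc4ccccc4o3)cc2)cc1`: 88000 nM
Compound 2 `O=S(=O)(Nc1ccc(-c2nc3ccccc3o2)cc1)c1cccc(O)c1`: > 100000 nM, a limit of the assay
Compound 3 `O=S(=O)(Nc1ccc(-c2nc3ccccc3o2)cc1)c1cccc(Cl)c1`: > 100000 nM, a limit of the assay

Compound 3 has no number in this assay, only a limit. The same holds for compound 2, so the set is dominated by the limit of > 100000 nM in this assay, at which 2 of the 3 values shown sit.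

Compound 4 `O=S(=O)(Nc1ccc(-c2nc3ccccc3o2)cc1)c1cccs1` carries thiophen-2-yl in place of 3-chlorophenyl on a sulfonyl sulfur.

Two measured exchanges on the sulfonyl sulfur bear on this change. The first is an at least 1.1-fold higher number from compound 1 to compound 2 (0.05 log units; that floor lies within the scatter). The second is an at least 1.1-fold higher number from compound 1 to compound 3 (0.05 log units; that floor lies within the scatter). Neither shows a change beyond the scatter, and neither involves thiophen-2-yl. The remaining comparison is a step that the two limits leave unreadable from compound 2 to compound 3. No step beyond the scatter is therefore expected in this assay, in either direction, and compound 4 may well yield only a limit again.

The expected change is a number no higher from compound 3 to compound 4 (the limit leaves the size open). For compound 4 the estimated value is 100000 nM, with an expected range from 50000 nM to 200000 nM.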

Compound 4, half-maximal cytotoxic concentration: > 100000 nM
Compound 4 gave a limit, no number (the forecaster's own chance of this, stated with the estimate: 70%); the middle value lies on the limit itself.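

In this assay the place on the sulfonyl sulfur also accepts a five-membered aromatic ring with 1 hetero atom, and compound 4 gives only a limit, > 100000 nM. Among these compounds, the one readable step is an at least 1.1-fold higher number from compound 1 to compound 4 (0.05 log units; that floor lies within the scatter), while the steps to compound 4 from compound 2 and from compound 3 cannot be read, as both ends are limits. The exchange of the six-membered aromatic ring for thiophen-2-yl therefore adds one more compound to the same ceiling: the limit of > 100000 nM in this assay, at which 3 of the 4 values shown sit.

On these data alone, how far compound 2, compound 3 and compound 4 lie beyond that limit remains open. So does whether a carboxylic acid or an amine on the aromatic ring, or a longer chain on the sulfonyl sulfur, would give a number rather than a limit.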